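This account rests on a few compounds, and the source may have more. Where it says the series, first, only, none or still open, it means among the compounds named here.

Measured compounds:
- compound 1 `Cc1ccccc1-c1nn(-c2ccc(F)cc2)cc1CNCCN1CCN(C)CC1`; in an ADME assay on Huh-7 cells (Homo sapiens) for cytotoxicity (a lower number here means that less compound is tolerated, a higher number that more compound is tolerated), compound 1 gives > 20000 nM, a limit of the assay
- compound 2 `Cc1ccc(-n2cc(CNCCN3CCN(C)CC3)c(-c3ccccc3C)n2)c(C)c1`; in this assay compound 2 gives > 20000 nM, likewise a limit

Compound 2 stands only at a limit, and every value shown sits at the limit of > 20000 nM in this assay, at which 2 of the 2 values shown sit. Within the data shown here, the step that the two limits leave unreadable from compound 1 to compound 2 therefore cannot be read, and no measured step gives a direction for the next change. Compound 3 `Cc1ccccc1-c1nn(-c2ccc(Br)cc2)cc1CNCCN1CCN(C)CC1` differs from compound 2 by 4-bromophenyl in place of 2,4-dimethylphenyl on an aromatic nitrogen. With both measured compounds at the limit, the expectation for compound 3 is no readable step, a step that the limit leaves unreadable from compound 2 to compound 3. Compound 3 is estimated at 25000 nM, between 10000 nM and 60000 nM, most likely again reported as a limit.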

Compound 3, half-maximal cytotoxic concentration: 9600 nM
Compound 3: the middle estimate sits 2.6-fold (0.42 log units) above what was measured; the whole stated range lies above it.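

The aryl group on the aromatic nitrogen can now be seen to matter in this assay: 4-bromophenyl in place of 2,4-dimethylphenyl gives an at least 2.0-fold lower number from compound 2 to compound 3 (0.31 log units; beyond the scatter). A single halogen exchange is enough to bring the value off the limit, as bromo in place of fluoro on an aromatic carbon gives an at least 2.0-fold lower number from compound 1 to compound 3 (0.31 log units; beyond the scatter). Both steps are only minimum sizes because their starting compounds stand at a limit: the limit of > 20000 nM in this assay, at which 2 of the 3 values shown sit.

On these data alone, how far either step extends beyond that minimum stays open. As far as these compounds go, it is also open whether chloro or methoxy in place of the bromo would stay off the limit.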